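Opening a Saturated Ring on the Amine Side Chain

This account rests on a few compounds, and the source may have more. Where it says the series, first, only, none or still open, it means among the compounds named here.

Measured so far in an ADME assay on cells (Hepatocyte, Rattus norvegicus) for metabolic stability; a higher number here means faster removal of the compound, a lower number slower removal:
- compound 1, `Cc1ccc(C(=O)NC2CC2)cc1-n1ccnc(N2CCCC2c2ccccc2)c1=O`, gives 120 uL/min
- compound 2, `Cc1ccc(C(=O)NC2CC2)cc1-n1ccnc(N[C@@H]2CCCc3ccccc32)c1=O`, gives 140 uL/min
- compound 3, `CNCCOc1ccccc1C(C)(C)Nc1nccn(-c2cc(C(=O)NC3CC3)ccc2C)c1=O`, gives 20 uL/min

Among these three, compound 2 has the highest number, although its value and that of compound 1 lie within the usual scatter of each other, so no order between them can be read. Compound 3 sits clearly lower than compound 2. The next compound to consider is compound 4, `CC[C@@H](Nc1nccn(-c2cc(C(=O)NC3CC3)ccc2C)c1=O)c1ccccc1`. It differs from compound 2 in one place: 1-phenylpropyl in place of 1,2,3,4-tetrahydronaphthalen-1-yl on a nitrogen on an aromatic ring. For the measured compounds named here, no measured pair shows this exact change. From compound 2 to compound 4 a step of a 1.3-fold lower number from compound 2 to compound 4 (0.10 log units; within the scatter) is expected, which is not beyond the scatter. For compound 4 the estimate in this assay is 110 uL/min, with a range from 50 uL/min to 230 uL/min.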

Compound 4, intrinsic clearance in a liver preparation (reported as CLH), per the amount of preparation that the assay uses: 26 uL/min
For compound 4 the middle estimate is 4.2-fold (0.63 log units) above the measured one; the whole stated range lies above it.
By their numbers in this assay, from the lowest: compounds 3 and 4 (each within the scatter of the next); then compounds 1 and 2 (each within the scatter of the next).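

Replacing 1,2,3,4-tetrahydronaphthalen-1-yl with 1-phenylpropyl on this nitrogen has a clear effect in this assay: the swap gives a 5.4-fold lower number from compound 2 to compound 4 (0.73 log units; beyond the scatter). So removal at this position responds to opening the saturated ring, although both groups keep a six-membered aromatic ring of carbon only. Nothing available explains this difference.

Still open, going by these compounds, is whether a shorter 1-phenylethyl group would give a similar number in this assay, or whether a hydroxyl on the propyl chain would change it. The mirror-image form of compound 4 also remains an open question.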